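Dropping the sulfonamide from compound 3: what remains?

The compounds below may be only part of what the source reports. "The series", "measured", "known", "first", "only" and "open" are said of these compounds alone.

Among the compounds with values here, compound 3 `CCOc1ccc(-c2cccc(S(=O)(=O)NC)c2)cc1` gives the lowest of the three numbers known so far: in an assay on COS-7 cells for inhibition of patatin-like phospholipase domain-containing protein 2 (Mus musculus), tested at 200 uM (a lower number here means less inhibition, a higher number more inhibition at the concentration tested (going by the name of the read-out)), compound 3 gives 47%, whereas compound 1 `CCOC(=O)c1cccc(-c2ccc(OCC)cc2)c1` gives 87% and compound 2 `CCOc1ccc(-c2cccc(S(=O)(=O)N(C)C)c2)cc1` gives 63%. The unmeasured compound 4 `CCOc1ccc(-c2ccccc2)cc1` differs from compound 3 by hydrogen in place of methylsulfamoyl on an aromatic carbon. Within the data shown here, two steps bear on this: a number 40 percentage points lower from compound 1 to compound 3 (beyond the scatter) and a number 16 percentage points lower from compound 2 to compound 3 (beyond the scatter), both showing that what sits at this aromatic carbon moves the read-out, and that a smaller group there gave a lower number. Among the measured compounds shown here, no measured compound has nothing at that position, so the step is expected to be a modest drop, a number 12 percentage points lower from compound 3 to compound 4 (beyond the scatter). For compound 4 the expected value is 35%, within a range from 10% to 62%.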

Compound 4, a percentage reported as inhibition, at one concentration (the size of the read-out at that concentration, not a potency): 35%
Compound 4: middle estimate and measured number agree at the digits printed; low and high end bracket the measured number.
By their numbers in this assay, from the lowest: compound 4; then compound 3; then compound 2; then compound 1.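

In this assay plain hydrogen on this aromatic carbon falls short of all three groups: a number 12 percentage points lower from compound 3 to compound 4 (beyond the scatter) on losing methylsulfamoyl, a number 28 percentage points lower from compound 2 to compound 4 (beyond the scatter) on losing dimethylsulfamoyl, and a number 52 percentage points lower from compound 1 to compound 4 (beyond the scatter) on losing ethoxycarbonyl. Compound 4 still gives 35% even with no such group, so the shared core alone accounts for part of the read-out, and each of the three groups adds to it. The data offer no reason for these gaps.

Still open, from the compounds shown here alone, is where a carboxylic acid, an amine or a primary amide would fall at this position. So is whether a longer ester chain would raise the number further.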